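This account rests on a few compounds, and the source may have more. Where it says the series, first, only, none or still open, it means among the compounds named here.

Working notes on the series. In a functional assay on HCT-116 cells (Homo sapiens) for cytotoxicity, read by hypoxanthine incorporation, with a stated time of 72 h, tested at 10 uM (a higher number here means more inhibition of growth at the concentration tested, a lower number less inhibition of growth), compound 1 `CC(C)C[C@@H]1NC(=O)[C@H](Cc2ccccc2)NC(=O)[C@H](CCCCNC(=O)OC(C)(C)C)NC(=O)[C@H](CC(C)C)NC(=O)[C@@H](C(C)C)NC1=O` gives 9% of growth inhibition, and compound 2 `CC(C)C[C@@H]1NC(=O)[C@H]([C@@H](OCc2ccccc2)c2ccccc2)NC(=O)[C@@H](Cc2ccccc2)NC(=O)[C@@H](CC(C)C)NC(=O)[C@H](C(C)C)N(C)C1=O` gives 64% in the same test. Compound 2 is therefore the higher of the two measured compounds, by a gap beyond the scatter, although the two differ in more than one place. Compound 3 `CC(C)C[C@@H]1NC(=O)[C@@H]([C@@H](OCc2ccccc2)c2ccccc2)NC(=O)[C@@H](Cc2ccccc2)NC(=O)[C@@H](CC(C)C)NC(=O)[C@H](C(C)C)N(C)C1=O` is the next one to consider: the two compounds have the same atoms and bonds and differ only in configuration as drawn: 1 of 6 stereo elements differ; a stereocentre at a saturated ring carbon is drawn S in compound 2 and R in compound 3, with a stereocentre at a saturated ring carbon drawn S in compound 2 and R in compound 3. Within the data shown here, no measured pair shows what such an inversion does in this assay, so the expectation is loose. Starting from compound 2 at 64% as the only close reference, a moderate loss of growth inhibition is expected, as the estimated step of a number 19 percentage points lower from compound 2 to compound 3 (beyond the scatter) indicates. For compound 3 the estimated value is 45%, within an expected range of 15% to 72%.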

Compound 3, percent growth inhibition at one concentration: 63%
Compound 3: middle estimate off by 18 percentage points, on the low side; low and high end bracket the measured number.
By their numbers in this assay, from the lowest: compound 1; then compounds 3 and 2 (each within the scatter of the next).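

In this assay, among these compounds, the inversion from S to R at the saturated ring carbon gives a number 1 percentage points lower from compound 2 to compound 3 (within the scatter), and this is the first step that changes one place only. Among the compounds shown here, at the single concentration tested, growth inhibition does not separate the two configurations at this stereocentre, which no earlier pair could show. The reading of this pair is confined to stereochemistry: the fact that compounds 2 and 3 differ only in the configuration as drawn

Still open, as far as these compounds go, is whether the same holds for inversion at the other stereocentres, and whether a full concentration-response comparison would separate the two configurations at this one. Also open, from the compounds shown here alone, is how an amine or a carboxylic acid carried at this ring carbon would behave in either configuration.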